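Swapping 3-methoxybenzyl for 4-methoxyphenyl on the Amine Nitrogen

This account rests on a few compounds, and the source may have more. Where it says the series, first, only, none or still open, it means among the compounds named here.

Compound 1, `Cc1ccc(Nc2ncc(Cl)c(Nc3ccccc3C)n2)cc1` — > 100000 nM (a limit of the assay)
Compound 2, `COc1cccc(CNc2nc(Nc3ccc(N4CCN(C)CC4)cn3)ncc2Cl)c1` — 19500 nM

Of the compounds shown here, two have been measured in a functional assay on MCF7 cells (Homo sapiens) for inhibition, read by CCK-8 assay, with a stated time of 48 h (on this read-out lower numbers stand for stronger inhibition of growth and higher numbers for weaker inhibition of growth), and they offer little to compare. Compound 1 gives no number in this assay but only a limit, > 100000 nM. That situation is summed up by the limit of > 100000 nM in this assay, at which 1 of the 2 values shown sits. Among the compounds with values here, compound 2 is therefore the only compound with an actual value in this assay, where compound 2 gives 19500 nM; no measured pair differing in a single place exists, so no step size has been observed at all.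

Compound 3, `COc1ccc(Nc2nc(Nc3ccc(N4CCN(C)CC4)cn3)ncc2Cl)cc1`, is the compound now awaiting measurement. It differs from compound 2 in one place: 4-methoxyphenyl in place of 3-methoxybenzyl on a nitrogen on an aromatic ring. The change shortens the link between the aromatic ring and the nitrogen by one carbon and moves the methoxy group from one position on the ring to another. Within the data shown here, with no measured analogue of this change, there is no ground to expect a shift beyond the usual scatter in either direction. The expected step is a 1.3-fold lower number from compound 2 to compound 3 (0.11 log units; within the scatter), within the scatter of this assay. Compound 3 is accordingly estimated at 15000 nM, with a likely range from 2500 nM to 80000 nM.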

Compound 3, concentration for 50% growth inhibition: 8450 nM
The estimate for compound 3 lay 1.8-fold (0.25 log units) above the measured number, and the stated range covers the measured number.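

In this assay, within the data shown here, replacing 3-methoxybenzyl with 4-methoxyphenyl on a nitrogen on an aromatic ring gives a 2.3-fold lower number from compound 2 to compound 3 (0.36 log units; beyond the scatter), the first step between measured compounds. Among these compounds, the step is modest, but it shows that the number responds to the group on this nitrogen, which the earlier compounds could not show. No measured property among the data shown accounts for the size or direction of this step.

As far as these compounds go, the change alters the link between the aromatic ring and the nitrogen and the place of the methoxy group in a single step, so the share of each remains open, and a 3-methoxyphenyl or a 4-methoxybenzyl group on the same nitrogen would be needed to separate them, while an unsubstituted phenyl would test whether the methoxy group matters at all. Compound 1 stands at a limit of the assay and differs from the other compounds in more than one place, so no step involving it can be read: the limit of > 100000 nM in this assay, at which 1 of the 3 values shown sits.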